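From compound 3 to its bromo analogue

The source may report more compounds than this note shows. Statements on the series, on what has been measured and on what is new or still open speak of the compounds shown alone.

In a functional assay on KYSE-450 cells (Homo sapiens) for inhibition, read by MTT assay, with a stated time of 48 h (a lower number here means a stronger inhibitor, a higher number a weaker inhibitor), compound 1 (`COc1ccc(CN(C(C)=O)c2cc(OC)c(OC)c(OC)c2)cc1O`) gives 160 nM, compound 2 (`C/C=C/C(=O)N(Cc1ccc(OC)c(O)c1)c1cc(OC)c(OC)c(OC)c1`) gives 67 nM and compound 3 (`COc1ccc(CN(C(=O)C[Se]C#N)c2cc(OC)c(OC)c(OC)c2)cc1O`) gives 280 nM. Compound 3 stands with compound 1 at the weak end of this small set, separated from it by a 1.8-fold higher number from compound 1 to compound 3 (0.24 log units; within the scatter), while compound 2 lies apart, at a 4.2-fold higher number from compound 2 to compound 3 (0.62 log units; beyond the scatter). Compound 4 (`COc1ccc(CN(C(=O)CBr)c2cc(OC)c(OC)c(OC)c2)cc1O`) arises through one change, on a saturated chain carbon bound to a carbonyl carbon: one bromine atom in place of a group of 3 heavy atoms (1 carbon, 1 nitrogen, 1 selenium; no ring), on a saturated chain carbon bound to a carbonyl carbon. The closest guide is the substitution on this carbon, a 1.8-fold higher number from compound 1 to compound 3 (0.24 log units; within the scatter). Among the measured compounds shown here, no measured compound carries bromine. Only a small change toward a lower number is therefore expected, within the scatter, as a 1.6-fold lower number from compound 3 to compound 4 (0.19 log units; within the scatter). Compound 4 is estimated at 180 nM, with an expected range from 60 nM to 500 nM.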

Compound 4, half-maximal inhibitory concentration: 120 nM
Compound 4: the middle estimate sits 1.5-fold (0.18 log units) above what was measured; measured number inside the range.
By their numbers in this assay, from the lowest: compounds 2, 4, 1 and 3 (each within the scatter of the next, the first and the last beyond it).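

Among the compounds shown here, on the saturated chain carbon bound to a carbonyl carbon, exchanging the selenium-bearing group for bromo gives a 2.3-fold lower number from compound 3 to compound 4 (0.37 log units; beyond the scatter), the only step at this position printed as beyond the scatter. Yet bromo in place of hydrogen gives only a 1.3-fold lower number from compound 1 to compound 4 (0.12 log units; within the scatter), within the scatter, as is a 1.8-fold higher number from compound 2 to compound 4 (0.25 log units; within the scatter), so compound 4 cannot be separated from either compound 1 or compound 2. Nothing available accounts for the difference between bromo and the selenium-bearing group.

The compounds shown leave open how chloro, an amine or a longer chain on this carbon would compare.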